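Biaryl series: replacing the distal ring with trifluoromethyl

The source may report more compounds than this note shows. Statements on the series, on what has been measured and on what is new or still open speak of the compounds shown alone.

Compound 3 `CC1CCN(C2CCN(S(=O)(=O)c3cccc(-c4ccc(Cl)cc4)c3)CC2)CC1` gives 15 nM in a functional assay on DLD-1 cells (Homo sapiens) for antiproliferative activity, read by CellTiter-Glo, with a stated time of 72 h; a higher number here means a weaker inhibitor, a lower number a stronger inhibitor; it holds the highest of the three numbers, though each neighbour sits within the scatter. Compound 1 `CC1CCN(C2CCN(S(=O)(=O)c3cccc(-c4ccccc4F)c3)CC2)CC1` gives 10 nM and compound 2 `CC1CCN(C2CCN(S(=O)(=O)c3cccc(-c4ccc(F)cc4)c3)CC2)CC1` gives 12 nM. For the measured compounds named here, the steps so far, a 1.2-fold higher number from compound 1 to compound 2 (0.08 log units; within the scatter), a 1.5-fold higher number from compound 1 to compound 3 (0.18 log units; within the scatter) and a 1.3-fold higher number from compound 2 to compound 3 (0.10 log units; within the scatter), all stay within the scatter and all swap one halogen for another on the outer ring. Compound 4 `CC1CCN(C2CCN(S(=O)(=O)c3cccc(C(F)(F)F)c3)CC2)CC1` differs from compound 3 by trifluoromethyl in place of 4-chlorophenyl on an aromatic carbon. No measured step removes the outer ring, so the three steps shown give no direct guide; the change is far larger than any of them. Compound 4 is expected to give a higher number, roughly an 8.0-fold higher number from compound 3 to compound 4 (0.90 log units; beyond the scatter), with a wide range. The estimate for compound 4 is 120 nM, between 20 nM and 800 nM.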

Compound 4, half-maximal inhibitory concentration: > 5000 nM
Compound 4 gave a limit, no number (the forecaster's own chance of this, stated with the estimate: 5%); middle value at least 41-fold (1.61 log units) away from the limit.
By their numbers in this assay, from the lowest: compounds 1, 2 and 3 (each within the scatter of the next). At a limit, above all of these: compound 4.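

Compound 4 gives a limit, not a number, in this assay: the limit of > 5000 nM in this assay, at which 1 of the 4 values shown sits.

Trading the outer ring for trifluoromethyl gives an at least 330-fold higher number from compound 3 to compound 4 (2.52 log units; beyond the scatter), an at least 410-fold higher number from compound 2 to compound 4 (2.61 log units; beyond the scatter) and an at least 500-fold higher number from compound 1 to compound 4 (2.69 log units; beyond the scatter), whereas the halogen swaps on that ring all stayed within the scatter. Among these four compounds, activity at this position therefore depends on the presence of the outer ring far more than on which halogen it carries.

Going by these compounds, it remains open whether a saturated cyclohexyl ring or a pyridine ring could stand in for the phenyl ring. On these data alone, the effect of an amine or a carboxylic acid on the outer ring is also open.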